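A few compounds are considered here, and "the series" means these few. Any claim that something is new, unique, unknown or untested is made for them only; others in the source may bear on it.

Compound 1 `CCN1CCC(n2cc(S(=O)(=O)C3=C(Cl)NC4SC=CN34)c3cccnc32)C1`: 1.4 nM
Compound 2 `CN1CCCC(n2cc(S(=O)(=O)c3cccc(F)c3)c3cccnc32)C1`: 4.7 nM
Compound 3 `CN1CCCC(n2cc(S(=O)(=O)c3cc(Cl)cc(Cl)c3)c3cccnc32)C1`: 3.9 nM

All three values come from an assay on HeLa cells for displacement of a labelled ligand from 5-hydroxytryptamine receptor 6 (Homo sapiens); a higher number here means a weaker inhibitor, a lower number a stronger inhibitor. Compound 3 stands second highest of the three numbers. Its nearest neighbour is compound 2, and the step of a 1.2-fold lower number from compound 2 to compound 3 (0.08 log units; within the scatter) is within the scatter. Compound 1, which differs from compound 3 at more than one place, among them the group on the sulfonyl sulfur, gives the lowest number of the three, and the gap between compound 3 and compound 1 lies beyond the scatter.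

Compound 4 `CN1CCCC(n2cc(S(=O)(=O)C3=C(Cl)NC4SC=CN34)c3cccnc32)C1` has not yet been measured in this assay. Relative to compound 3 the change is a group of 9 heavy atoms (5 carbon, 2 nitrogen, 1 sulfur, 1 chlorine; 2 five-membered non-aromatic rings with 2 hetero atoms each) in place of a group of 8 heavy atoms (6 carbon, 2 chlorine; one six-membered aromatic ring of carbon only), on a sulfonyl sulfur. Within the data shown here, the one single-point step measured so far, from compound 2 to compound 3, swaps one aryl group for another on the same sulfur and is small; it gives little guidance for exchanging an aryl group for the bicyclic group. Among the measured compounds shown here, compound 1 carries that same bicyclic group, but alongside a second difference, so no clean step can be separated out; its value nonetheless points toward a lower number. Compound 4 is therefore expected to show a step of a 1.8-fold lower number from compound 3 to compound 4 (0.25 log units; within the scatter) in this assay toward a lower number, of a size that may not clearly exceed the scatter. The estimate for compound 4 in this assay is 2.2 nM, with a range from 0.8 nM to 6 nM.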

Compound 4, inhibition constant: 2 nM
Estimate against measurement, compound 4: 1.1-fold (0.04 log units) above, and the stated range covers the measured number.
By their numbers in this assay, from the lowest: compounds 1, 4, 3 and 2 (each within the scatter of the next, the first and the last beyond it).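

In this assay the bicyclic group on the sulfonyl sulfur, read against 3,5-dichlorophenyl with 1-methylpiperidin-3-yl held constant, gives a step that stays within the scatter (a 2.0-fold lower number from compound 3 to compound 4 (0.29 log units; within the scatter)), so these two groups are not told apart at this position. Against 3-fluorophenyl the same exchange gives the first single-place change at this sulfur to pass the scatter, though only modestly (a 2.4-fold lower number from compound 2 to compound 4 (0.37 log units; beyond the scatter)), whereas the swap between the two aryl groups had not passed it. Among these compounds, the first clean reading on the aromatic nitrogen, 1-methylpiperidin-3-yl in place of 1-ethylpyrrolidin-3-yl, also stays within the scatter (a 1.4-fold higher number from compound 1 to compound 4 (0.15 log units; within the scatter)), so the gap between compound 1 and the aryl sulfones cannot be assigned to that amine group on these numbers.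

Still open, going by these compounds, are how a plain phenyl or a version of the bicyclic group without its chlorine would read on the sulfonyl sulfur, and how an open-chain amine such as 2-(dimethylamino)ethyl would read on the aromatic nitrogen. Nothing shown gives a reason for any of these numbers.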